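Removing the bromo group from compound 1

The source may report more compounds than this note shows. Statements on the series, on what has been measured and on what is new or still open speak of the compounds shown alone.

In a functional assay on K562 cells (Homo sapiens) for inhibition, read by spectrophotometry and sulforhodamine B assay, with a stated time of 48 h (on this read-out higher numbers stand for weaker inhibition of growth and lower numbers for stronger inhibition of growth), compound 1 `Cc1ccc(N2C(=O)CS/C2=N/N=C/c2c[nH]c3ccc(Br)cc23)cc1` gives 10 nM, a strong result. Compound 3 `S=C(N/N=C/c1c[nH]c2ccccc12)Nc1cccc2ccccc12` gives 10 nM, so compound 1 stands level with it. Compound 2 `O=C1CS/C(=N/N=C/c2c[nH]c3ccc(Br)cc23)N1c1cccc2ccccc12` reads > 100000 nM, which is a limit of the assay and not a number.

Compound 4 `Cc1ccc(N2C(=O)CS/C2=N/N=C/c2c[nH]c3ccccc23)cc1` has not yet been measured. It differs from compound 1 in a single place: hydrogen in place of bromo on an aromatic carbon. The change is hydrogen in place of bromo on an aromatic carbon.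

For the measured compounds named here, no measured pair shows this change on its own, so its size has to be judged from indirect evidence. Compound 3, which carries no bromo group, gives 10 nM in this assay, so a value this low does not depend on having that group. Going by the values given here, the spread across only three compounds is very wide, however, so the expectation must stay broad. A small weakening is expected in this assay, meaning a somewhat higher number, and it may not exceed the scatter. The expected move is a 3.0-fold higher number from compound 1 to compound 4 (0.48 log units; beyond the scatter). For compound 4 the estimate is 30 nM, with an expected range from 5 nM to 1000 nM.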

Compound 4, concentration for 50% growth inhibition: > 100000 nM
Compound 4 gave a limit, no number (the forecaster's own chance of this, stated with the estimate: 5%); middle value at least 3300-fold (3.52 log units) away from the limit.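

In this assay, this single exchange of bromo for hydrogen on an aromatic carbon, with nothing else altered, gives an at least 10000-fold higher number from compound 1 to compound 4 (4.00 log units; beyond the scatter), so the strong growth inhibition of compound 1 depends heavily on what sits at this position. For the compounds shown here, compound 4 reads > 100000 nM, a limit of the assay and not a number, and it is not alone: the limit of > 100000 nM in this assay, at which 2 of the 4 values shown sit. Compound 3 also lacks the bromo group, but it differs from compound 4 in more than one place, so its value says nothing direct about this change, and the pair of compound 1 and compound 4 is the first direct reading of it.

On these data alone, whether a chloro, methoxy or amine group on the same aromatic carbon would keep the strength of compound 1 stays open, so it cannot yet be said whether bromo itself is needed or whether other groups would also serve in place of hydrogen. Going by these compounds alone, this is also the only pair showing the change, which leaves open whether the same collapse would appear with a different group on the shared core.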